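The source may hold more compounds than are shown below. What is called first, only, known or untested is meant among the compounds shown, and "the series" means these compounds.

Compound 1 `CN1CCN(c2ccc(/C=C3/SC(Nc4ccccc4)=NC3=O)cc2)CC1` gives 0.35 ug/mL in a physicochemical assay (Homo sapiens) for solubility, with a stated time of 18 h, at pH 7.4; on this read-out lower numbers stand for lower solubility and higher numbers for higher solubility. Compound 2 `CN1CCN(c2ccc(/C=C3/SC(Nc4ccc(Oc5ccccc5)cc4)=NC3=O)cc2)CC1` gives 0.1 ug/mL in this assay.

Among the measured compounds shown here, compound 1 stands highest of the two numbers; its nearest neighbour is compound 2, and the single measured step, a 3.5-fold lower number from compound 1 to compound 2 (0.54 log units; beyond the scatter), runs downward and beyond the scatter. Compound 3 `CN1CCN(c2ccc(/C=C3/SC(N(c4ccccc4)c4ccccc4)=NC3=O)cc2)CC1` differs from compound 1 by phenyl in place of hydrogen on a nitrogen on an aromatic ring, a six-membered aromatic ring of carbon only entering at the nitrogen rather than on an aromatic carbon. For the measured compounds named here, that one step is the only guide, so a downward move of similar size is expected in this assay. Compound 3 is therefore estimated at 0.1 ug/mL, with a range of 0.03 ug/mL to 0.3 ug/mL, meaning a 3.5-fold lower number from compound 1 to compound 3 (0.54 log units; beyond the scatter).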

Compound 3, solubility: 0.11 ug/mL
The estimate for compound 3 lay 1.1-fold (0.04 log units) below the measured number; low and high end bracket the measured number.
By their numbers in this assay, from the lowest: compounds 2 and 3 (each within the scatter of the next); then compound 1.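

In this assay, phenyl in place of hydrogen on a nitrogen on an aromatic ring gives a 3.2-fold lower number from compound 1 to compound 3 (0.50 log units; beyond the scatter). A step beyond the scatter is thus now seen at this nitrogen too, and it runs in the same downward direction as the phenoxy change on an aromatic carbon, a 3.5-fold lower number from compound 1 to compound 2 (0.54 log units; beyond the scatter). No measured evidence accounts for this step.

Only phenyl has been seen replacing hydrogen at this nitrogen, so a single step describes the position. As far as these compounds go, compound 1 gives 0.35 ug/mL, and whether a methyl group or a chain ending in a carboxylic acid would lower or raise that number remains open.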